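A few compounds are considered here, and "the series" means these few. Any claim that something is new, unique, unknown or untested is made for them only; others in the source may bear on it.

Compound 2 `O=C(O)CC/C=C\CC1COC(c2ccsc2)OC1c1cccnc1` stands as the weaker of the two measured compounds: in an assay for inhibition of Thromboxane-A synthase (Homo sapiens), using microsomes (a lower number here means a stronger inhibitor, a higher number a weaker inhibitor), compound 2 gives 500 nM. Within the data shown here, its only measured neighbour is compound 1 `N#Cc1ccc(C2OCC(C/C=C\CCC(=O)O)C(c3cccnc3)O2)cc1`, which in this assay gives 24 nM; the step between them, a 21-fold higher number from compound 1 to compound 2 (1.32 log units; beyond the scatter), shows that exchanging the group on the saturated ring carbon can move the number a long way.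

Compound 3 `O=C(O)CC/C=C\CC1COC(c2ccco2)OC1c1cccnc1` is the next case in this series. Here (furan-2-yl in place of thiophen-3-yl on a saturated ring carbon). Among the measured compounds shown here, no measured step exchanges one five-membered aromatic ring for another, so the step from compound 1 to compound 2 bears on this change only indirectly: it shows that this position responds to substitution, but that step replaced a six-membered ring bearing a nitrile with a five-membered ring, a larger change than the present one. For compound 3 a step of a 1.3-fold higher number from compound 2 to compound 3 (0.11 log units; within the scatter) is therefore expected, that is, a small move in this assay, not clearly beyond the scatter. Compound 3 is estimated at 650 nM, with a range from 200 nM to 2000 nM.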

Compound 3, half-maximal inhibitory concentration: 164 nM
The estimate for compound 3 lay 4.0-fold (0.60 log units) above the measured number, outside the stated range (below it).
By their numbers in this assay, from the lowest: compound 1; then compound 3; then compound 2.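

The exchange of one five-membered aromatic ring for another, with the same heavy-atom, donor and acceptor counts, still registers at this saturated ring carbon between two ring oxygen atoms: in this assay furan-2-yl in place of thiophen-3-yl gives a 3.0-fold lower number from compound 2 to compound 3 (0.48 log units; beyond the scatter), beyond the scatter. The position therefore tells these two five-membered rings apart, yet furan-2-yl does not match 4-cyanophenyl, as a 6.8-fold higher number from compound 1 to compound 3 (0.83 log units; beyond the scatter) shows, so the order set by the first step holds while the gap narrows. Nothing in the information available explains why the furan-2-yl and thiophen-3-yl rings differ.

Furan-2-yl and thiophen-3-yl differ in both the ring hetero atom and the point of attachment, so the compounds shown cannot separate these two changes; thiophen-2-yl or furan-3-yl at this carbon would do so. As far as these compounds go, it also stays open how much of the lower number of compound 1 belongs to the six-membered ring and how much to its nitrile, a question that an unsubstituted phenyl group would address.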